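Shortening the branched alkyl group of compound 2

The source may report more compounds than this note shows. Statements on the series, on what has been measured and on what is new or still open speak of the compounds shown alone.

Compound 1 `CCC(CC)(CC)/N=C(\NC#N)Nc1cc(Cl)cc(Cl)c1`: in a functional assay with Cavia porcellus as the target (on this read-out lower numbers stand for an effect already at smaller amounts and higher numbers for an effect only at larger amounts of compound), compound 1 gives only a limit, > 1 uM.
Compound 2 `CCC(C)(CC)/N=C(\NC#N)Nc1cc(Cl)cc(C#N)c1`: in this assay compound 2 gives 0.016 uM.
Compound 3 `CC(C)C(C)(C)/N=C(\NC#N)Nc1cc(Cl)cc(C#N)c1`: in this assay compound 3 gives 0.19 uM.

Of the two values that are numbers, compound 2 stands lowest; the nearest is compound 3, and the step of a 12-fold higher number from compound 2 to compound 3 (1.07 log units; beyond the scatter) lies well beyond the scatter. The value for compound 1 is a limit of the assay and not a number (the limit of > 1 uM in this assay, at which 1 of the 3 values shown sits), so it does not rank against the others.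

Compound 4 `CCC(C)(C)/N=C(\NC#N)Nc1cc(Cl)cc(C#N)c1` differs from compound 2 by hydrogen in place of methyl on a saturated chain carbon, two bonds along the chain from a double-bonded nitrogen. For the measured compounds named here, no measured pair shows exactly this change. Going by the values given here, the only measured step at the same place, from compound 2 to compound 3, rearranges the branching of the group without changing its size, and it already costs a large step in this assay. That step shows that this position answers strongly to the shape of the group, but it does not tell the direction for simply removing a methyl. The account therefore expects a step that is modest and probably upward, with wide uncertainty in both directions. For compound 4 the estimate in this assay is 0.04 uM, with a range from 0.01 uM to 0.2 uM. The expected step is a 2.5-fold higher number from compound 2 to compound 4 (0.40 log units; beyond the scatter).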

Compound 4, concentration for half-maximal effect: 0.02 uM
Compound 4: the middle estimate sits 2.0-fold (0.30 log units) above what was measured; low and high end bracket the measured number.
By their numbers in this assay, from the lowest: compounds 2 and 4 (each within the scatter of the next); then compound 3. At a limit, above all of these: compound 1.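

Taking away the methyl, a 1.3-fold higher number from compound 2 to compound 4 (0.10 log units; within the scatter), leaves 1-ethyl-1-methylpropyl and 1,1-dimethylpropyl indistinguishable in this assay, so at this place the ethyl and the methyl of the group can be exchanged without a step that can be told from the scatter. Set beside a 12-fold higher number from compound 2 to compound 3 (1.07 log units; beyond the scatter), the second new step, a 9.5-fold lower number from compound 3 to compound 4 (0.98 log units; beyond the scatter), shows that among the three compounds with a number, only the 1,1,2-trimethylpropyl group of compound 3 stands apart, and that the place does not answer to every change in the group with a large step. Nothing given here explains why these groups differ as they do.

From the compounds shown here alone, it remains open how far the group can be cut down, since a tert-butyl or an isopropyl group, or a cyclopentyl ring, in place of 1,1-dimethylpropyl would test this directly. The value of compound 1, > 1 uM, is a limit and not a number, and that compound differs from the others in more than one place, so it cannot be read against them.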